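Methoxy to fluoro on the shared core

This account rests on a few compounds, and the source may have more. Where it says the series, first, only, none or still open, it means among the compounds named here.

Compound 1 `COc1cc(C#N)cc(C#Cc2cccc(C)n2)c1` gives 3.4 nM in an in vitro functional assay on HEK293-A cells for agonist activity at metabotropic glutamate receptor 5 (Rattus norvegicus), read by ELISA (on this read-out lower numbers stand for stronger inhibition and higher numbers for weaker inhibition), the lowest of the three numbers in hand. Compound 2 `N#Cc1cccc(C#Cc2cccc(C#N)n2)c1` gives 20 nM, and compound 3 `CCCCc1cccc(C#Cc2cccc(C#N)c2)n1` gives 700 nM. Going by the values given here, the only single-place step measured is a 35-fold higher number from compound 2 to compound 3 (1.54 log units; beyond the scatter); it concerns a butyl for a cyano group and does not touch the change now considered. Compound 4 `Cc1cccc(C#Cc2cc(F)cc(C#N)c2)n1` differs from compound 1 by fluoro in place of methoxy on an aromatic carbon. Among the compounds with values here, no measured step covers a methoxy-to-fluoro exchange, so the expectation rests on compound 1 alone and is held close to it, with a slight drift toward a higher number allowed. Compound 4 is therefore expected at 6 nM, within 2 nM to 20 nM, which corresponds to a 1.8-fold higher number from compound 1 to compound 4 (0.25 log units; within the scatter).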

Compound 4, half-maximal inhibitory concentration: 2.4 nM
Beside the measured number, compound 4's estimate is 2.5-fold (0.40 log units) above it, within the range that was stated.
By their numbers in this assay, from the lowest: compounds 4 and 1 (each within the scatter of the next); then compound 2; then compound 3.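

In this assay, fluoro in place of methoxy on this aromatic carbon, meta to a cyano group, comes with a 1.4-fold lower number from compound 1 to compound 4 (0.15 log units; within the scatter) and leaves the two compounds within the scatter. For this pair, the methoxy oxygen and carbon are therefore not required to keep the number in this range. Nothing on hand gives a reason for this tolerance.

Going by these compounds, whether chloro, ethoxy, a dimethylamino group or a carboxylic acid would hold the number on this carbon stays open. Also open, on these data alone, is whether the exchange gives a similar result alongside the butyl group of compound 3 or the cyano group of compound 2.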